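Swapping a Pyridinylmethyl Arm for Cyclohexyl on a Piperazine

This account rests on a few compounds, and the source may have more. Where it says the series, first, only, none or still open, it means among the compounds named here.

Of the compounds shown here, two have been measured. Compound 1 `Nc1ccccc1NC(=O)c1ccc(CSC(=S)N2CCN(Cc3ccncc3)CC2)cc1` was tested in a functional assay on MGC-803 cells (Homo sapiens) for antiproliferative activity, read by CCK-8 assay, with a stated time of 72 h, tested at 8 uM (a lower number here means a weaker effect, a higher number a stronger effect of the compound at the concentration tested), and compound 1 gives 79.3% there. Compound 2 `Nc1ccccc1NC(=O)c1ccc(CSC(=S)N(Cc2ccccc2)Cc2ccccc2)cc1` differs from compound 1 at several points. In this assay compound 2 gives 30.7%. Of these two numbers, compound 1 stands highest, and its distance from compound 2 lies beyond the usual scatter of the measurement, so compound 1 is the stronger of the two at this concentration.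

Compound 3 `Nc1ccccc1NC(=O)c1ccc(CSC(=S)N2CCN(C3CCCCC3)CC2)cc1` has not yet been measured. It departs from compound 1 in one place: cyclohexyl in place of (pyridin-4-yl)methyl on an amine nitrogen in a ring. The arm that carries the aromatic ring and its hydrogen-bond acceptor is replaced by a saturated carbon ring carrying no such acceptor.

Among the compounds with values here, no measured pair shows what this particular exchange does. The expected step in this assay is a modest decrease, of the size a number 14.3 percentage points lower from compound 1 to compound 3 (beyond the scatter), which may not even reach beyond the scatter. Compound 3 is therefore expected to give about 65% in this assay, within a range from 35% to 85%.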

Compound 3, a percentage reported as inhibition, at one concentration (the size of the read-out at that concentration, not a potency): 75.3%
For compound 3 the middle estimate is 10.3 percentage points below the measured one, and the stated range covers the measured number.
By their numbers in this assay, from the lowest: compound 2; then compounds 3 and 1 (each within the scatter of the next).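

In this assay, putting cyclohexyl in place of (pyridin-4-yl)methyl on an amine nitrogen in a ring gives a number 4 percentage points lower from compound 1 to compound 3 (within the scatter) and so leaves the two compounds indistinguishable at this concentration. For this pair, then, the read-out holds up when the arm loses both its aromatic ring and its hydrogen-bond acceptor and gains a non-aromatic ring of carbon only, which is something that the earlier comparison could not show, since its two compounds differ at several points. Why these two different arms read alike cannot be said, as nothing at hand speaks to a cause.

As far as these compounds go, a percentage at a single concentration is not a potency, so it remains open whether compound 1 and compound 3 would also stay together at lower concentrations. From the compounds shown here alone, it is also open how far this tolerance extends on the same nitrogen, for example to a small methyl group, a longer chain ending in a hydroxyl group, or a group carrying a carboxylic acid.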